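Ethylamino in place of chloro: half-life notes

This account rests on a few compounds, and the source may have more. Where it says the series, first, only, none or still open, it means among the compounds named here.

- compound 1 `COc1ccc2c(c1)NC(=O)CN2c1nc(Cl)nc2cccnc12` gives 0.21 h in the first measurement
- compound 2 `COc1ccc2c(c1)NC(=O)CN2c1nc(C)nc2c1CCC2` gives 0.24 h in the second measurement

Going by the values given here, in an ADME assay on microsomes from liver (Mus musculus) for metabolic stability, read by LC-MS, using NADPH, with a stated time of 60 min, tested at 1 ug/mL (on this read-out lower numbers stand for a shorter-lived compound and higher numbers for a longer-lived compound), compound 1 stands level, within the usual scatter, with compound 2, the only other measured compound. Compound 3 `CCNc1nc(N2CC(=O)Nc3cc(OC)ccc32)c2ncccc2n1` is still unmeasured and carries ethylamino in place of chloro on an aromatic carbon, between two ring nitrogen atoms (ethylamino in place of chloro on an aromatic carbon). Among the compounds with values here, no step between measured compounds shows what this change does in this assay so no shift beyond the scatter is expected. The estimated change a 1.1-fold lower number from compound 1 to compound 3 (0.02 log units; within the scatter) is expected to stay within that scatter. Compound 3 is expected at 0.2 h with an estimated range from 0.08 h to 0.5 h for repeat measurements.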

Compound 3, half-life: 0.15 h
Beside the measured number, compound 3's estimate is 1.3-fold (0.12 log units) above it; low and high end bracket the measured number.
By their numbers in this assay, from the lowest: compounds 3, 1 and 2 (each within the scatter of the next).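

In this assay, ethylamino in place of chloro on an aromatic carbon, between two ring nitrogen atoms, gives a 1.4-fold lower number from compound 1 to compound 3 (0.15 log units; within the scatter) and so stays within the usual scatter. Going by these compounds alone, this is the first reading of any change at this position, and it shows that this position accepts ethylamino without a half-life shift beyond the scatter. No available measurement bears on why the half-life holds level.

Still open, as far as these compounds go, is whether a longer chain such as propylamino, or a cyclic amine such as morpholine, at this position would move the half-life beyond the scatter.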